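Fluorine on the aniline ring of two styryl sulfonamides

A few compounds are considered here, and "the series" means these few. Any claim that something is new, unique, unknown or untested is made for them only; others in the source may bear on it.

Of the compounds shown here, three have been measured in a functional assay on K562 cells (Homo sapiens) for cytotoxicity, read by trypan blue exclusion, with a stated time of 96 h; a lower number here means a stronger inhibitor, a higher number a weaker inhibitor. Compound 2 `COc1ccc(NS(=O)(=O)/C=C/c2c(OC)cc(OC)cc2OC)cc1` gives 75 nM, the lowest of the three numbers. Compound 3 `COc1ccc(NS(=O)(=O)/C=C/c2c(F)c(F)c(F)c(F)c2F)cc1` gives 5000 nM, and compound 1 `COc1ccc(NS(=O)(=O)/C=C/c2c(F)c(F)c(F)c(F)c2F)cc1F` gives 10000 nM. Compound 3 and compound 1 differ in one place, and the change from one to the other is fluoro in place of hydrogen on an aromatic carbon. The step it made, a 2.0-fold higher number from compound 3 to compound 1 (0.30 log units; within the scatter), lies within the scatter of this kind of measurement. Compound 2 and compound 3 carry different cores; how those two cores differ is not broken down here, and their values show a wide gap between them.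

Compound 4 `COc1cc(OC)c(/C=C/S(=O)(=O)Nc2ccc(OC)c(F)c2)c(OC)c1` has not yet been measured. It stands to compound 2 as compound 1 stands to compound 3, since the change from compound 2 to compound 4 is fluoro in place of hydrogen on an aromatic carbon. Among the compounds with values here, this is the same change as the one from compound 3 to compound 1, made on the same kind of aromatic carbon with the same neighbouring groups.

Within the data shown here, because the only measured instance of this change, a 2.0-fold higher number from compound 3 to compound 1 (0.30 log units; within the scatter), stayed within the scatter, the step from compound 2 to compound 4 in this assay is expected to be small, about a 1.5-fold higher number from compound 2 to compound 4 (0.17 log units; within the scatter). On that basis compound 4 is estimated to give about 110 nM, with a likely range from 50 nM to 250 nM.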

Compound 4, half-maximal inhibitory concentration: 75 nM
Compound 4: the middle estimate sits 1.5-fold (0.17 log units) above what was measured; measured number inside the range.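

In this assay the new step reads no change at the digits printed from compound 2 to compound 4 (within the scatter), and set beside the earlier step on the other core, it shows no difference that can be told from the scatter: the same change on two cores in this assay, a 2.0-fold higher number (0.30 log units; within the scatter) from compound 3 to compound 1 and no change at the digits printed (within the scatter) from compound 2 to compound 4, 2.0-fold (0.30 log units) apart, within the scatter of two such steps Within this small set, then, the change from 4-methoxyphenyl to 3-fluoro-4-methoxyphenyl carries from one core to the other, and on both cores it leaves the number within the scatter of its parent. Within the data shown here, this does not show that the change is neutral in general, since it rests on only two pairs, one place on the ring and one cell assay, and it gives no reason why the two steps agree.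

The compounds shown leave open whether a different group in that same place, such as a chlorine, a hydroxyl, an amine or a nitrile, would also leave the number unmoved on both cores. They also leave open whether the step would hold on a core whose styryl ring carries other groups, or whether replacing the methoxy group with a longer chain such as propoxy would alter how the fluoro change reads.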